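A short side chain gives way to a longer one

The compounds below may be only part of what the source reports. "The series", "measured", "known", "first", "only" and "open" are said of these compounds alone.

In a functional assay on DU-145 cells (Homo sapiens) for cytotoxicity, read by MTT assay (on this read-out higher numbers stand for weaker inhibition and lower numbers for stronger inhibition), compound 3 (`CC(C)=CC[C@@H](OCCO)C1=CC(=O)c2c(O)ccc(O)c2C1=O`) gives 9900 nM and compound 2 (`CC(C)=CC[C@@H](OCC(C)O)C1=CC(=O)c2c(O)ccc(O)c2C1=O`) gives 16100 nM. Among the measured compounds shown here, the only single-place change measured so far is a 1.6-fold lower number from compound 2 to compound 3 (0.21 log units; within the scatter), so these two compounds cannot be told apart. Compound 1 (`CCCCC(CC(=O)O[C@H](CC=C(C)C)C1=CC(=O)c2c(O)ccc(O)c2C1=O)OC(C)=O`) gives 67700 nM, a clearly higher number than either. Compound 3 therefore sits with compound 2 at the stronger end of the three values, well away from compound 1.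

Compound 4 (`CCCCC(C)(O)CC(=O)O[C@H](CC=C(C)C)C1=CC(=O)c2c(O)ccc(O)c2C1=O`) has not yet been measured. It has (2-hydroxy-2-methylhexyl)carbonyl in place of the 2-hydroxyethyl of compound 3, on an oxygen on a saturated carbon ((2-hydroxy-2-methylhexyl)carbonyl in place of 2-hydroxyethyl on an oxygen on a saturated carbon). The measured step from methyl to hydrogen is a far smaller edit, so it offers little guidance here. The better guide is compound 1, which also carries a long chain with a carbonyl on that oxygen and gives 67700 nM. For the measured compounds named here, that value points towards a higher number, meaning weaker inhibition, though with only one such compound the expectation remains loose. The expected size of the change is a 3.0-fold higher number from compound 3 to compound 4 (0.48 log units; beyond the scatter). The estimate for compound 4 is 30000 nM, with an expected range from 9000 nM to 90000 nM.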

Compound 4, half-maximal inhibitory concentration: 76500 nM
Compound 4: the middle estimate sits 2.6-fold (0.41 log units) below what was measured, and the stated range covers the measured number.
By their numbers in this assay, from the lowest: compounds 3 and 2 (each within the scatter of the next); then compounds 1 and 4 (each within the scatter of the next).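

In this assay, this position on an oxygen on a saturated carbon now shows a change that lies beyond the scatter. Putting (2-hydroxy-2-methylhexyl)carbonyl in place of 2-hydroxyethyl gives a 7.7-fold higher number from compound 3 to compound 4 (0.89 log units; beyond the scatter), and putting it in place of 2-hydroxypropyl gives a 4.8-fold higher number from compound 2 to compound 4 (0.68 log units; beyond the scatter), so this larger edit weakens inhibition in a way the small methyl-to-hydrogen edit could not show. The chain itself tolerates a different kind of change, since 1-hydroxy-1-methylpentyl in place of 1-acetoxypentyl gives a 1.1-fold higher number from compound 1 to compound 4 (0.05 log units; within the scatter), which leaves those two compounds indistinguishable; nothing given here explains the weaker inhibition.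

The edit brings in a carbonyl and a longer chain together, so an acetyl group on that oxygen and a plain hexyl chain on it would be needed to tell which of the two goes with the higher number. On these data alone, it also remains open how an amine in place of the hydroxyl of the 2-hydroxyethyl would read in this assay.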